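Moving a Methyl Group on a Pyridinyl Sulfonyl Fragment

The compounds below may be only part of what the source reports. "The series", "measured", "known", "first", "only" and "open" are said of these compounds alone.

Measured compounds:
compound 1 `CNCc1cn(S(=O)(=O)c2ccccn2)c(-c2cccnc2F)c1F`: 95%
compound 2 `CNCc1cn(S(=O)(=O)c2ncccc2C)c(-c2cccnc2F)c1F`: 54%

Of the compounds shown here, two have been measured in a functional assay on the whole organism (strain Jcl:Sprague-Dawley) for inhibition, with Rattus norvegicus as the target, with stated times of 3 min and 3 h, at a dose of 1 mg/kg by the intravenous route; on this read-out lower numbers stand for less inhibition and higher numbers for more inhibition at the one dose given (going by the name of the read-out). In this assay, among the compounds with values here, compound 1 gives 95%, while compound 2 gives 54%, and the single measured step, a number 41 percentage points lower from compound 1 to compound 2 (beyond the scatter), is a methyl in place of hydrogen on an aromatic carbon. Within the data shown here, compound 2 therefore stands at the lower of the two numbers, with compound 1 the only neighbour and well beyond the scatter above it.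

Compound 3 `CNCc1cn(S(=O)(=O)c2cccc(C)n2)c(-c2cccnc2F)c1F` has not yet been measured. It differs from compound 2 as follows: 6-methylpyridin-2-yl in place of 3-methylpyridin-2-yl on a sulfonyl sulfur. Among the measured compounds shown here, the methyl group is kept but the same atoms are joined differently, so the one measured step, which adds a methyl rather than relocating one, bears only loosely on this change. For the measured compounds named here, no measured pair shows what moving the methyl along the ring does, so the direction is open. With compound 2 at 54% as the anchor, the step is expected to be a number 8 percentage points higher from compound 2 to compound 3 (within the scatter), and compound 3 is estimated at 62%, within a range from 25% to 92%.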

Compound 3, a percentage reported as inhibition, in the whole organism at one dose (the size of the read-out at that dose, not a potency): 91%
The estimate for compound 3 lay 29 percentage points below the measured number, within the range that was stated.
By their numbers in this assay, from the lowest: compound 2; then compounds 3 and 1 (each within the scatter of the next).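

In this assay, the outcome depends on where the methyl sits on the ring and not merely on its presence: with the same atoms joined differently, there is a number 37 percentage points higher from compound 2 to compound 3 (beyond the scatter) on going from 3-methylpyridin-2-yl to 6-methylpyridin-2-yl on the sulfonyl sulfur. The large loss seen earlier on adding a methyl is therefore not general to this ring, for adding one to give the 6-methylpyridin-2-yl group produces only a number 4 percentage points lower from compound 1 to compound 3 (within the scatter) and leaves the two compounds level in this read-out. No accompanying measurement bears on why the two methyl isomers part so widely, and the reason stays unknown.

The compounds shown leave open whether the 6-methylpyridin-2-yl result extends to other groups in place of that methyl, such as an ethyl, a methoxy or a chlorine, or to an amine, which could show how much room for change this part of the ring allows. With a single dose behind every number, they also leave open whether compound 1 and compound 3 would remain level at a lower dose, where any separation between them might first appear.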